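Shortening the Ether Chain of Compound 1

A few compounds are considered here, and "the series" means these few. Any claim that something is new, unique, unknown or untested is made for them only; others in the source may bear on it.

Measured compounds:
compound 1 `CCCCOCCn1c(N2CCCN(C)CC2)nc2ccccc21`: 10 nM
compound 2 `CCCCCCn1c(N2CCN(C)CC2)nc2ccccc21`: 26 nM
compound 3 `COCCCn1c(N2CCN(C)CC2)nc2ccccc21`: 860 nM

Of the compounds shown here, three with a shared core have been tested in a functional assay on ileum for inhibition of histamine H1 receptor (Cavia porcellus); a lower number here means a stronger inhibitor, a higher number a weaker inhibitor. Compound 1 gives the lowest number, 10 nM. Compound 2 gives 26 nM, and compound 3 gives 860 nM, both higher than compound 1 beyond the scatter. Among the compounds with values here, the only measured single change, a 33-fold higher number from compound 2 to compound 3 (1.52 log units; beyond the scatter), shows that altering the chain on the core nitrogen can move this assay strongly. Compound 4 `CCCOCCn1c(N2CCCN(C)CC2)nc2ccccc21` differs from compound 1 by hydrogen in place of methyl on a saturated chain carbon, three bonds along the chain from an oxygen on a saturated carbon, a smaller trimming than that between compound 2 and compound 3. A modest rise in this assay, at most slightly beyond the scatter, is therefore expected: a 2.0-fold higher number from compound 1 to compound 4 (0.30 log units; within the scatter). Compound 4 is estimated at 20 nM, with a range from 7 nM to 60 nM.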

Compound 4, half-maximal inhibitory concentration: 16 nM
Compound 4: middle estimate off by 1.3-fold (0.10 log units), on the high side; the measured number falls inside the stated range.
By their numbers in this assay, from the lowest: compounds 1, 4 and 2 (each within the scatter of the next, the first and the last beyond it); then compound 3.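

In this assay, butyl to propyl gives a 1.6-fold higher number from compound 1 to compound 4 (0.20 log units; within the scatter) and cannot be told from scatter, so losing this one methyl, three bonds along the chain from an oxygen on a saturated carbon, leaves the number effectively in place. Within the data shown here, the earlier large step, a 33-fold higher number from compound 2 to compound 3 (1.52 log units; beyond the scatter), therefore has no counterpart in this smaller trim. No measurement shown here gives a reason for this tolerance.

Still open, from the compounds shown here alone, is whether a shorter ethyl in place of the butyl would hold the number as well. A longer chain such as hexyl, or an amine on the chain, remains equally untested in the compounds shown.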